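The source may hold more compounds than are shown below. What is called first, only, known or untested is meant among the compounds shown, and "the series" means these compounds.

Working notes on the sulfonyl-hydroxyguanidine series

In a functional assay on Hs-578T cells (Homo sapiens) (on this read-out lower numbers stand for stronger inhibition of growth and higher numbers for weaker inhibition of growth), compound 2 `COc1cc(CSc2cc(Cl)c(-c3nc(-c4ccccc4)no3)cc2S(=O)(=O)NC(=N)NO)cc(OC)c1OC` gives 7410 nM, the highest of the three numbers in hand. Its nearest neighbour is compound 3 `N=C(NO)NS(=O)(=O)c1cc(-c2nc(-c3ccccc3)no2)c(Cl)cc1SCc1ccccc1`, which in this assay gives 2550 nM; the step of a 2.9-fold lower number from compound 2 to compound 3 (0.46 log units; beyond the scatter) comes from phenyl in place of 3,4,5-trimethoxyphenyl on the saturated chain carbon bound to sulfur. Compound 1 `N=C(NO)NS(=O)(=O)c1cc(-c2nnc(-c3ccc(Cl)cc3)s2)c(Cl)cc1SCc1ccccc1` gives 2510 nM in this assay, but it differs from compound 3 in two places, so its closeness to compound 3 cannot be read as a single step.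

Compound 4 `COc1cc(CSc2cc(Cl)c(-c3nc(-c4ccc(Cl)cc4)no3)cc2S(=O)(=O)NC(=N)NO)cc(OC)c1OC` differs from compound 2 by chloro in place of hydrogen on an aromatic carbon, that is, phenyl to 4-chlorophenyl on the oxadiazole. Within the data shown here, no measured step covers this change alone; the only pair that carries the chloro, compound 1 against compound 3, shows two values within the usual scatter of each other while also changing the heteroaromatic ring. The step of a 1.1-fold lower number from compound 2 to compound 4 (0.02 log units; within the scatter) is therefore expected to stay within the scatter. Compound 4 is estimated at 7000 nM in this assay, with a range of 2500 nM to 18000 nM.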

Compound 4, concentration for 50% growth inhibition: 4170 nM
Compound 4: the middle estimate sits 1.7-fold (0.22 log units) above what was measured; low and high end bracket the measured number.
By their numbers in this assay, from the lowest: compounds 1, 3, 4 and 2 (each within the scatter of the next, the first and the last beyond it).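

In this assay, among these compounds, the change from 3-phenyl-1,2,4-oxadiazol-5-yl to 3-(4-chlorophenyl)-1,2,4-oxadiazol-5-yl gives a 1.8-fold lower number from compound 2 to compound 4 (0.25 log units; within the scatter) and is the first reading of this change on its own. Earlier, the chloro appeared only in compound 1 against compound 3, where the heteroaromatic ring changed as well; here that ring and the 3,4,5-trimethoxyphenyl group stay fixed, and chloro on this aromatic carbon does not move the number beyond the scatter. No data at hand bear on this result.

Still open, from the compounds shown here alone, is whether an amine or a carboxylic acid on the same aromatic carbon would leave the number within the scatter. Also open, going by these compounds, is whether chloro would read the same with phenyl in place of 3,4,5-trimethoxyphenyl on the chain carbon bound to sulfur.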